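This account rests on a few compounds, and the source may have more. Where it says the series, first, only, none or still open, it means among the compounds named here.

Measured so far:
compound 1, `Fc1ccc(/C=C/CN2CCC(CCOC(c3ccc(F)cc3)c3ccc(F)cc3)CC2)cc1`, 15.1 nM in an assay on cell membranes from brain for inhibition of sodium-dependent dopamine transporter (Rattus norvegicus); on this read-out lower numbers stand for stronger inhibition and higher numbers for weaker inhibition
compound 2, `Fc1ccc(/C=C/CN2CCC(CCOC(c3ccccc3)c3ccccc3)CC2)cc1`, 10.8 nM
compound 3, `c1ccc(CCCN2CCC(CCOC(c3ccccc3)c3cccs3)CC2)cc1`, 6 nM

Compound 3 shows the lowest number of the three. Compound 2 lies nearest, within the scatter; compound 1 lies furthest, beyond it. Going by the values given here, compound 1 and compound 2 themselves give values that lie within the scatter of each other, and no step is recorded for that pair.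

Compound 4, `Fc1ccc(C(OCCC2CCN(CCCc3ccccc3)CC2)c2cccs2)cc1`, has not yet been measured in this assay. It differs from compound 3 by fluoro in place of hydrogen on an aromatic carbon. With no measured step of this kind in the series to lean on, only a small step is expected, a 1.2-fold higher number from compound 3 to compound 4 (0.07 log units; within the scatter), with no direction that would reach beyond the scatter. Compound 4 is therefore expected to give about 7 nM, with a likely range from 3 nM to 16 nM.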

Compound 4, half-maximal inhibitory concentration: 11.7 nM
For compound 4 the middle estimate is 1.7-fold (0.22 log units) below the measured one, within the range that was stated.
By their numbers in this assay, from the lowest: compounds 3, 2, 4 and 1 (each within the scatter of the next, the first and the last beyond it).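

In this assay the change from phenyl to 4-fluorophenyl gives a 2.0-fold higher number from compound 3 to compound 4 (0.29 log units; within the scatter). Going by these compounds alone, this is the first single-place step, and it shows that fluoro is accommodated at this carbon, para to a large group, without a shift beyond the scatter. No measured property bears on this step.

Going by these compounds, whether chloro, methoxy or trifluoromethyl at the same carbon would give a step beyond the scatter remains open. So does whether fluoro gives a similar step on a different aromatic carbon.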